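The source may hold more compounds than are shown below. What is called first, only, known or untested is meant among the compounds shown, and "the series" means these compounds.

Working notes on the series

Three compounds of the series carry a measurement in an ADME assay on THP-1 cells (Homo sapiens) for cytotoxicity, read by flow cytometry and propidium iodide staining, with a stated time of 72 h; on this read-out lower numbers stand for stronger inhibition and higher numbers for weaker inhibition. Compound 1 `COc1ccccc1-c1cc(=O)c2cc(NC(C)=O)ccc2o1` gives 50000 nM. Compound 3 `COc1ccccc1-c1cc(=O)c2cc(N)ccc2o1` gives 74000 nM. Compound 2 `COc1ccc(-c2cc(=O)c3cc(NC(C)=O)ccc3o2)cc1` gives 74000 nM, level with compound 3 at the digits recorded; together these two hold the highest numbers of the three, and both lie within the scatter of compound 1. The difference between the core of compound 1 and the core of compound 2 is not broken down here. Compound 4 `COc1ccc(-c2cc(=O)c3cc(N)ccc3o2)cc1` has not yet been measured in this assay.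

One structural change occurs twice among the compounds shown. From compound 1 to compound 3 it is hydrogen in place of acetyl on a nitrogen on an aromatic ring, and the step it made was a 1.5-fold higher number from compound 1 to compound 3 (0.17 log units; within the scatter). Going by the values given here, from compound 2 to compound 4 the change is hydrogen in place of acetyl on a nitrogen on an aromatic ring, the same change at the same kind of place, so the earlier step is the only guide to the new one. Among the compounds with values here, only a single prior step exists for this change, and it stays within the scatter, so nothing in the data points to a shift in either direction beyond that.

The step is therefore expected to be a 1.2-fold higher number from compound 2 to compound 4 (0.09 log units; within the scatter), which rests on the step of a 1.5-fold higher number from compound 1 to compound 3 (0.17 log units; within the scatter) staying within the scatter. Compound 4 is estimated at 90000 nM, with a range from 45000 nM to 180000 nM in this assay.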

Compound 4, half-maximal inhibitory concentration: 124000 nM
Estimate against measurement, compound 4: 1.4-fold (0.14 log units) below; low and high end bracket the measured number.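

In this assay the acetamido to amino change, hydrogen in place of acetyl on a nitrogen on an aromatic ring, gives a 1.7-fold higher number from compound 2 to compound 4 (0.22 log units; within the scatter). Set beside the earlier step, the change carries from the core of compound 1 to the core of compound 2 with no difference that can be told apart: the same change on two cores in this assay, a 1.5-fold higher number (0.17 log units; within the scatter) from compound 1 to compound 3 and a 1.7-fold higher number (0.22 log units; within the scatter) from compound 2 to compound 4, 1.1-fold (0.05 log units) apart, within the scatter of two such steps. This agreement is only an agreement between two small steps, each within the scatter, so it shows neither a real shift on removing the acetyl nor that the change would behave the same way on any core other than these two.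

The compounds shown leave open whether a different group on that nitrogen, such as a longer acyl chain, a sulfonyl group or a simple alkyl chain, would move the number in this cytotoxicity read-out beyond the scatter in either direction. They also leave open whether the same acetamido to amino change keeps its small size on a core in which the methoxy group gives way to another group, such as a hydroxyl or a chlorine.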